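Replacing a furan with a carboxyphenyl on a shared core

This account rests on a few compounds, and the source may have more. Where it says the series, first, only, none or still open, it means among the compounds named here.

Compound 1 `Cc1ccccc1-n1nc(C)c2c1NC(=O)[C@H](C)S[C@@H]2c1ccc(-c2ccoc2)cc1` gives 3500 nM in an assay on isolated protein for agonist activity at Bile acid receptor (Homo sapiens), read by AlphaScreen, with a stated time of 30 min (a lower number here means that less compound is needed, a higher number that more compound is needed for the effect), the highest of the three numbers here. Compound 3 `Cc1nn(-c2ccccc2I)c2c1C(c1ccc(Oc3ccccc3)cc1)SC(C)C(=O)N2` gives 1300 nM and compound 2 `CCCc1ccccc1-n1nc(C)c2c1NC(=O)[C@H](C)S[C@@H]2c1ccc(Oc2ccccc2)cc1` gives 1100 nM in this assay, both beyond the scatter from compound 1. Compound 4 `Cc1ccccc1-n1nc(C)c2c1NC(=O)[C@H](C)S[C@@H]2c1ccc(-c2ccc(C(=O)O)cc2)cc1` has not been measured. It differs from compound 1 in one place: 4-carboxyphenyl in place of furan-3-yl on an aromatic carbon. For the measured compounds named here, no measured pair shows this change, so the expectation rests on compound 1 alone. A step from compound 1 to compound 4 of a 3.9-fold lower number from compound 1 to compound 4 (0.59 log units; beyond the scatter) is expected, meaning a lower number, though the range is wide. Compound 4 is estimated at 900 nM, between 250 nM and 3500 nM.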

Compound 4, half-maximal effective concentration: "not active" (no number reported)
For compound 4 the study gives words and no number, so the estimate cannot be set against anything.
By their numbers in this assay, from the lowest: compounds 2 and 3 (each within the scatter of the next); then compound 1.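

For the compounds shown here, compound 4 is reported only in words, as not active, so no step from compound 1 to compound 4 can be read. What lies behind this result stays open, with nothing shown here to explain it.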